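Pyrazolyl chalcones: carbonyl-side aryl swap on compound 1

The source may hold more compounds than are shown below. What is called first, only, known or untested is meant among the compounds shown, and "the series" means these compounds.

Measured so far:
compound 1 `COc1cc(-c2cc(/C=C/C(=O)c3ccc(N)cc3)[nH]n2)cc(OC)c1OC`: 26%
compound 2 `COc1ccc(-c2cc(/C=C/C(=O)c3ccc(N)cc3)[nH]n2)cc1OC`: 56%
compound 3 `COc1ccc(-c2cc(/C=C/C(=O)c3cc(OC)c(OC)c(OC)c3)[nH]n2)cc1OC`: 7%

In a functional assay on TK-10 cells (Homo sapiens) for cytotoxicity, read by sulforhodamine B assay, with a stated time of 48 h, tested at 10 uM (a higher number here means a weaker effect of the compound at the concentration tested, a lower number a stronger effect), compound 1 gives 26% and stands second highest of the three numbers. The nearest number is that of compound 3, which lies lower and beyond the scatter; the furthest is that of compound 2, higher and beyond the scatter. Within the data shown here, the one step of a single change, a number 30 percentage points higher from compound 1 to compound 2 (beyond the scatter), concerns the aryl on the pyrazole side, not the carbonyl side.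

Compound 4 `COc1ccc(C(=O)/C=C/c2cc(-c3cc(OC)c(OC)c(OC)c3)n[nH]2)cc1OC` differs from compound 1 as follows: 3,4-dimethoxyphenyl in place of 4-aminophenyl on a carbonyl carbon. Among the measured compounds shown here, no measured step covers this exact change. For the measured compounds named here, what bears on it is only the pair of compound 2 and compound 3, which differ in the aryl on the carbonyl carbon among other things: compound 2 shows 56%, and compound 3 shows 7%, a much lower number with a methoxy-bearing aryl at the carbonyl. On that basis a lower number is expected for compound 4, giving an estimated step of a number 12 percentage points lower from compound 1 to compound 4 (beyond the scatter). The estimate for compound 4 in this assay is 14%, with a range from 3% to 35%.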

Compound 4, a percentage reported as activity, at one concentration (the size of the read-out at that concentration, not a potency): 100%
For compound 4 the middle estimate is 86 percentage points below the measured one; the whole stated range lies below it.
By their numbers in this assay, from the lowest: compound 3; then compound 1; then compound 2; then compound 4.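

In this assay, among these compounds, the exchange of 4-aminophenyl for 3,4-dimethoxyphenyl on the carbonyl carbon gives a number 74 percentage points higher from compound 1 to compound 4 (beyond the scatter) and is the first direct reading of this position, since the only earlier single change, a number 30 percentage points higher from compound 1 to compound 2 (beyond the scatter), lay on the other aryl. With the rest of the core of compound 1 held fixed, this position therefore strongly affects the read-out, and 3,4-dimethoxyphenyl here goes with a much weaker effect at the concentration tested than 4-aminophenyl. Nothing measured on these compounds accounts for the size of this step.

Going by these compounds, whether the step follows the loss of the amine or the arrival of the two methoxy groups remains open. A plain phenyl or a 4-hydroxyphenyl on the same carbonyl carbon would separate these two readings.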